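From tert-Butyl to Cyclohexyl on the Urea Nitrogen

A few compounds are considered here, and "the series" means these few. Any claim that something is new, unique, unknown or untested is made for them only; others in the source may bear on it.

The set shares one core, carried in compound 1 `NC(=O)N1CCN(C(=S)SCc2cn(Cc3ccccc3F)nn2)CC1` and compound 2 `CC(C)(C)NC(=O)N1CCN(C(=S)SCc2cn(Cc3ccccc3F)nn2)CC1`. In a functional assay on MCF7 cells (Homo sapiens) for cytotoxicity, read by MTT assay, with a stated time of 72 h (a lower number here means a stronger inhibitor, a higher number a weaker inhibitor), compound 1 gives only a limit of > 128000 nM. In this assay, among the measured compounds shown here, compound 2 gives 18800 nM, the only number measured so far, so it stands as the single fixed point of the series. For the measured compounds named here, the one measured step, an at least 6.8-fold lower number from compound 1 to compound 2 (0.83 log units; beyond the scatter), shows that tert-butyl on the amide-type nitrogen moves the read-out from a limit to a number, though its true size is unknown because of the limit of > 128000 nM in this assay, at which 1 of the 2 values shown sits.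

Compound 3 `O=C(NC1CCCCC1)N1CCN(C(=S)SCc2cn(Cc3ccccc3F)nn2)CC1` differs from compound 2 by cyclohexyl in place of tert-butyl on an amide-type nitrogen. Going by the values given here, the measured step bears on this only loosely, since it swapped hydrogen for a carbon group rather than one carbon group for another; no measured pair separates tert-butyl from cyclohexyl. He therefore expects a step within the scatter in this assay, a 1.4-fold lower number from compound 2 to compound 3 (0.16 log units; within the scatter). Compound 3 is expected to give about 13000 nM, between 4000 nM and 45000 nM.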

Compound 3, half-maximal inhibitory concentration: 85000 nM
Compound 3: the middle estimate sits 6.5-fold (0.82 log units) below what was measured, and the stated range ends below it.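

In this assay, cyclohexyl in place of tert-butyl gives a 4.5-fold higher number from compound 2 to compound 3 (0.66 log units; beyond the scatter), so at this amide-type nitrogen the identity of the carbon group matters, not merely its presence. Carrying a carbon group here therefore does not by itself bring the lower number seen with tert-butyl, and in this one pair the group with more carbon and a ring goes with the higher number. Against the unsubstituted urea, the compounds show an at least 1.5-fold lower number from compound 1 to compound 3 (0.17 log units; that floor lies within the scatter), a floor only, and the true size of that step cannot be told because of an assay limit: the limit of > 128000 nM in this assay, at which 1 of the 3 values shown sits.

On these data alone, whether the branching of tert-butyl or the ring of cyclohexyl drives the gap stays open. An isopropyl, an n-hexyl or a phenyl group on this nitrogen is not among the compounds shown, and any of these could help separate the two.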